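The source may report more compounds than this note shows. Statements on the series, on what has been measured and on what is new or still open speak of the compounds shown alone.

Measured so far:
- compound 1, `[N-]=[N+]=NCC(O)Cn1c(=O)n(C2OC(CO)[C@@H](O)[C@H]2O)c2nc(N)nc(O)c21`: 39 uM
- compound 2, `C=CCn1c(=O)n([C@H]2CO[C@@H](CO)C2)c2nc(N)nc(O)c21`: 83 uM
- compound 3, `C=CCn1c(=O)n(CCCC)c2nc(N)nc(O)c21`: 2 uM

All three share one core and were read in a functional assay (B cells) with Mus musculus as the target; on this read-out lower numbers stand for an effect already at smaller amounts and higher numbers for an effect only at larger amounts of compound. Compound 1 stands second highest of the three numbers; its nearest neighbour is compound 2, beyond the scatter, and its furthest is compound 3, a large gap in the other direction.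

Compound 4, `N#Cc1cccc(Cn2c(=O)n(C3OC(CO)[C@@H](O)[C@H]3O)c3nc(N)nc(O)c32)c1`, is not yet measured. Against compound 1 the change is 3-cyanophenyl in place of 2-azido-1-hydroxyethyl on a saturated chain carbon bound to an aromatic nitrogen.

Going by the values given here, the only measured step, a 42-fold lower number from compound 2 to compound 3 (1.62 log units; beyond the scatter), sits on the other aromatic nitrogen of the core, where the ring bearing the hydroxymethyl is exchanged for a plain chain; it says nothing direct about the group on the saturated chain carbon that is changed here. Among the compounds with values here, no measured pair varies that group while the sugar-like ring is kept, so there is no step to lean on for size or direction. The expectation is therefore broad: a modest move toward smaller numbers is thought plausible, but a result within the scatter of compound 1 is just as defensible.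

Compound 4 is estimated at 15 uM, with a range of 3 uM to 80 uM; this estimate means a step of a 2.6-fold lower number from compound 1 to compound 4 (0.41 log units; beyond the scatter).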

Compound 4, concentration for half-maximal effect: 3 uM
For compound 4 the middle estimate is 5.0-fold (0.70 log units) above the measured one, and the stated range covers the measured number.
By their numbers in this assay, from the lowest: compounds 3 and 4 (each within the scatter of the next); then compound 1; then compound 2.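

Working notes: in this assay, replacing 2-azido-1-hydroxyethyl with 3-cyanophenyl on a saturated chain carbon bound to an aromatic nitrogen gives a 13-fold lower number from compound 1 to compound 4 (1.11 log units; beyond the scatter) and so shows that the read-out responds strongly to this position, while the earlier step of a 42-fold lower number from compound 2 to compound 3 (1.62 log units; beyond the scatter) concerned a change placed directly on an aromatic nitrogen. The change also shows that the hydrogen-bond donor of the leaving group is not required for a number beyond the scatter on the lower side, as the entering group has none and brings a six-membered aromatic ring of carbon only. No measurement on hand gives a reason for the step.

Still open, going by these compounds, is whether the aromatic ring or the nitrile accounts for the step, a question that plain benzyl on the same core, or 3-aminobenzyl and 3-carboxybenzyl, would address. Also open, on these data alone, is whether 3-cyanobenzyl keeps the same effect when the sugar-bearing group of compound 4 is exchanged for the butyl chain carried by compound 3.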